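From compound 3 to compound 4: one added methyl

This account rests on a few compounds, and the source may have more. Where it says the series, first, only, none or still open, it means among the compounds named here.

The series is read in a functional assay on L1210 cells (Mus musculus) for inhibition (on this read-out higher numbers stand for weaker inhibition and lower numbers for stronger inhibition), starting from compound 1 (`C#CCN(Cc1ccc2nc(N)nc(O)c2c1)c1ccc(C(=O)O)cc1`). Compound 1 gives > 200 uM, which is a limit. Compound 2 (`C#CCN(Cc1ccc2nc(N)nc(O)c2c1)c1ccc(CCCC(=O)O)cc1`) gives > 10 uM, also a limit. Compound 3 (`C#CCN(Cc1ccc2nc(N)nc(O)c2c1)c1ccc(C(=O)NCC(=O)O)cc1`) gives > 100 uM, again a limit. It therefore has no number, and neither do the other two compounds.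

Compound 4 (`C#CCN(Cc1ccc2nc(N)nc(O)c2c1)c1ccc(C(=O)NC(C)C(=O)O)cc1`) differs from compound 3 by one change: methyl in place of hydrogen on a saturated chain carbon bound to an amide-type nitrogen and a carbonyl carbon. This is methyl in place of hydrogen on a saturated chain carbon bound to an amide-type nitrogen and a carbonyl carbon, turning (carboxymethyl)carbamoyl into (1-carboxyethyl)carbamoyl.

Within the data shown here, no measured step covers this change. The closest are a step that the two limits leave unreadable from compound 1 to compound 3 and a step that the two limits leave unreadable from compound 2 to compound 3, and a step that the two limits leave unreadable from compound 1 to compound 2 adds no size either. An estimated a number no higher from compound 3 to compound 4 (the limit leaves the size open) is expected to be small, with no direction readable from these limits. The expected value for compound 4 is 100 uM, within an estimated range of 25 uM to 400 uM.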

Compound 4, concentration for 50% inhibition: > 10 uM
Compound 4: a limit, no number (the forecaster's own chance of this, stated with the estimate: 70%); the middle value does not contradict the limit.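

Compound 4, like compound 1, compound 2 and compound 3, carries only a limit and not a number, so none of its steps to those compounds can be read. The compounds shown leave open whether the added methyl or any other change here shifts inhibition at all.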